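Swapping a Methoxyphenyl for a Nitrophenyl on the Sulfonamide

This account rests on a few compounds, and the source may have more. Where it says the series, first, only, none or still open, it means among the compounds named here.

Compound 1 `COc1cccc(S(=O)(=O)NC2=NCCN2C(=S)SN2CCn3c2nsc3=S)c1` carries a 3-methoxyphenyl on the sulfonyl sulfur of its sulfonamide, attached to a shared core. In a functional assay on KYSE-510 cells (Homo sapiens) for antiproliferative activity, read by crystal violet staining, with a stated time of 96 h (a higher number here means a weaker inhibitor of growth, a lower number a stronger inhibitor of growth), compound 1 gives >= 20000 nM, which is a limit of the assay and not a number. Two relatives keep the same core. Compound 2 `COc1ccc(OC)c(S(=O)(=O)NC2=NCCN2C(=S)SN2CCn3c2nsc3=S)c1` adds a methoxy on an aromatic carbon; in this assay compound 2 gives >= 20000 nM, again a limit. Compound 3 `O=S(=O)(NC1=NCCN1C(=S)SN1CCn2c1nsc2=S)c1cccc(OC(F)(F)F)c1` carries trifluoromethyl in place of methyl on the oxygen of the aromatic ring; in this assay compound 3 gives >= 20000 nM, also a limit. The step that the two limits leave unreadable from compound 1 to compound 2 and the step that the two limits leave unreadable from compound 1 to compound 3 cannot be sized because the limit of >= 20000 nM in this assay, at which 3 of the 3 values shown sit, covers every result so far.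

Compound 4 `O=[N+]([O-])c1ccc(S(=O)(=O)NC2=NCCN2C(=S)SN2CCn3c2nsc3=S)cc1` differs from compound 1 by 4-nitrophenyl in place of 3-methoxyphenyl on a sulfonyl sulfur. Among the measured compounds shown here, no measured step follows this exact change; the two measured steps show only that altering the aryl group left each result at the assay limit. Compound 4 is therefore expected to show no measurable growth inhibition within the tested range, with an expected step of a number no higher from compound 1 to compound 4 (the limit leaves the size open) that stays inside the scatter. The estimate for compound 4 is 20000 nM, with an expected range from 8000 nM to 60000 nM.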

Compound 4, concentration for 50% growth inhibition: >= 20000 nM
Compound 4 ended at the assay's limit; the forecaster's own chance of this, stated with the estimate: 80%; the middle value lies on the limit itself.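

Among the compounds shown here, no step from compound 1 or compound 2 to compound 4 can be read, because all four results sit at one assay limit: the limit of >= 20000 nM in this assay, at which 4 of the 4 values shown sit.

The compounds shown leave open whether, in this assay, any aryl group on the sulfonyl sulfur of this shared core changes growth inhibition at all, and by how much.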